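A few compounds are considered here, and "the series" means these few. Any claim that something is new, unique, unknown or untested is made for them only; others in the source may bear on it.

Compound 1 `Cc1c(C(=O)Nc2ccc(Oc3ncnc4[nH]cc(-c5ccccc5)c34)c(F)c2)c(=O)c2cc(Cl)ccc2n1C` is the weakest of the three measured compounds in an assay on isolated protein for inhibition of tyrosine-protein kinase receptor UFO (Homo sapiens), read by FRET and Z'-LYTE, with a stated time of 1.5 h; on this read-out lower numbers stand for stronger inhibition and higher numbers for weaker inhibition: compound 1 gives 1890 nM. Compound 2 `CCn1c(C)c(C(=O)Nc2ccc(Oc3ncnc4[nH]cc(-c5ccccc5)c34)c(F)c2)c(=O)c2cc(C)ccc21` gives 150 nM in this assay, and compound 3 `CCCn1c(C)c(C(=O)Nc2ccc(Oc3ncnc4[nH]cc(-c5ccccc5)c34)c(F)c2)c(=O)c2cc(C)ccc21` gives 530 nM. Among the measured compounds shown here, the only measured single-point step, a 3.5-fold higher number from compound 2 to compound 3 (0.55 log units; beyond the scatter), concerns the chain on the aromatic nitrogen and not the ring carbon changed here. Compound 4 `C=C(C)c1ccc2c(c1)c(=O)c(C(=O)Nc1ccc(Oc3ncnc4[nH]cc(-c5ccccc5)c34)c(F)c1)c(C)n2C` differs from compound 1 by 1-methylethenyl in place of chloro on an aromatic carbon. For the measured compounds named here, no measured step bears on this change at this position, so the expectation rests on compound 1 alone and is wide, with a step of a 1.5-fold lower number from compound 1 to compound 4 (0.16 log units; within the scatter) in this assay expected. Compound 4 is therefore estimated at 1300 nM in this assay, within a range from 350 nM to 5000 nM.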

Compound 4, half-maximal inhibitory concentration: 170 nM
The estimate for compound 4 lay 7.6-fold (0.88 log units) above the measured number; the whole stated range lies above it.
By their numbers in this assay, from the lowest: compounds 2 and 4 (each within the scatter of the next); then compound 3; then compound 1.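

In this assay, the aromatic carbon that carries chloro in compound 1 proves sensitive to its substituent: replacing chloro with 1-methylethenyl gives an 11-fold lower number from compound 1 to compound 4 (1.05 log units; beyond the scatter) on the shared core. This position therefore accepts the larger, all-carbon group, and the change goes with stronger inhibition. No evidence is available on why this step is so large.

On these data alone, whether the double bond matters remains open, and an isopropyl group on this carbon would address that. As far as these compounds go, how an amine or a carboxylic acid would behave here is also open.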